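Moving the Methoxy Group Around the Aromatic Ring

The compounds below may be only part of what the source reports. "The series", "measured", "known", "first", "only" and "open" are said of these compounds alone.

Compound 1 `CCOCc1cccc(C[C@H](O)/C=C/[C@H]2[C@H](O)CC(=O)[C@@H]2SCCCSCC(=O)O)c1`: > 10000 nM
Compound 2 `COc1ccccc1C[C@H](O)/C=C/[C@H]1[C@H](O)CC(=O)[C@@H]1SCCCSCC(=O)O`: > 10000 nM

Both values come from an assay on CHO cells for displacement of a labelled ligand from prostacyclin receptor (Homo sapiens); on this read-out higher numbers stand for weaker inhibition and lower numbers for stronger inhibition. For compound 1 the value is a limit of the assay rather than a number. For compound 2 the value is likewise a limit of the assay. What has been seen so far is the limit of > 10000 nM in this assay, at which 2 of the 2 values shown sit. The step that the two limits leave unreadable from compound 1 to compound 2 therefore cannot be sized. Compound 2 stands at that limit, without a number of its own.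

Compound 3 `COc1ccc(C[C@H](O)/C=C/[C@H]2[C@H](O)CC(=O)[C@@H]2SCCCSCC(=O)O)cc1` differs from compound 2 by 4-methoxyphenyl in place of 2-methoxyphenyl on a saturated chain carbon, two bonds along the chain from a double-bonded chain carbon and an oxygen on a saturated carbon. No readable step bears on this change, so the expectation is simply that compound 3 remains at the limit. Compound 3 is expected to give 12000 nM, within 3000 nM to 50000 nM. The expected step is a step that the limit leaves unreadable from compound 2 to compound 3.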

Compound 3, inhibition constant: > 10000 nM
Compound 3 gave a limit, no number (the forecaster's own chance of this, stated with the estimate: 75%); the middle value lies beyond the limit too.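

No step can be read among compound 1, compound 2 and compound 3, since each gave only a limit of the assay, not a number: the limit of > 10000 nM in this assay, at which 3 of the 3 values shown sit.

As far as these compounds go, how far each compound lies past that limit stays open, and so does whether 4-methoxyphenyl in place of 2-methoxyphenyl changes inhibition at all.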